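The source may report more compounds than this note shows. Statements on the series, on what has been measured and on what is new or still open speak of the compounds shown alone.

Compound 1, `CC(C)C(NC(=O)NO)C(=O)NC1CCCCC1`, and compound 2, `CCC(C)C(NC(=O)NO)C(=O)NC1CCCCC1`, are the two measured compounds that share one core; compound 3, `CC(C)C(NC(=O)n1nnc2ccccc21)C(=O)NC1CCCC1`, has a different core and a smaller ring on the amide nitrogen. In a functional assay on HEp-2 cells (Homo sapiens) for inhibition (on this read-out lower numbers stand for stronger inhibition and higher numbers for weaker inhibition), compound 1 gives > 100000 nM, which is a limit of the assay and not a number. In this assay compound 2 likewise gives > 100000 nM, again a limit rather than a measured number. In this assay, within the data shown here, compound 3 gives 60300 nM, the only actual number among the three.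

The change from compound 1 to compound 2 is methyl in place of hydrogen on a saturated chain carbon, three bonds along the chain from an amide-type nitrogen and a carbonyl carbon. Its step, a step that the two limits leave unreadable from compound 1 to compound 2, cannot be sized because both of its end points sit at the limit of > 100000 nM in this assay, at which 2 of the 3 values shown sit. The difference between the two cores, that of compound 1 and that of compound 3, is not broken down here.

Compound 4, `CCC(C)C(NC(=O)n1nnc2ccccc21)C(=O)NC1CCCC1`, has not yet been measured. It carries the same change on the core of compound 3 that compound 2 carries on the core of compound 1: methyl in place of hydrogen on a saturated chain carbon, three bonds along the chain from an amide-type nitrogen and a carbonyl carbon, the place being the same word for word. Nothing measured tells how large this change is, so the expectation rests mainly on the starting point, the value of compound 3, 60300 nM, with a step of about a 1.2-fold higher number from compound 3 to compound 4 (0.06 log units; within the scatter) expected. For compound 4 in this assay the estimate is 70000 nM, with a likely range from 25000 nM to 200000 nM, and a real chance that only a limit is reported.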

Compound 4, half-maximal inhibitory concentration: 55700 nM
Compound 4: the middle estimate sits 1.3-fold (0.10 log units) above what was measured; the measured number falls inside the stated range.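

In this assay, the change from isopropyl to sec-butyl gives a 1.1-fold lower number from compound 3 to compound 4 (0.03 log units; within the scatter), so on this core the two values cannot be told apart and the added methyl leaves no readable mark. The same change on the core of compound 1 cannot be read, because compound 1 and compound 2 each stand at a limit of the assay and not at a number: the limit of > 100000 nM in this assay, at which 2 of the 4 values shown sit. The result therefore describes one core only, and it shows neither that the change behaves alike on the two cores nor that it behaves differently.

The compounds shown carry only isopropyl or sec-butyl at this place, so it stays open whether a longer chain such as n-hexyl, or a chain ending in an amine or a carboxylic acid, would move the number on the core of compound 3 by more than the usual scatter. From the compounds shown here alone, it also stays open how much the core alone matters, since compound 1 and compound 3 differ both in the core and in the size of the ring on the amide nitrogen.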